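This account rests on a few compounds, and the source may have more. Where it says the series, first, only, none or still open, it means among the compounds named here.

Measured so far:

compound 1 `CCCCN(Cc1ccc(C(=O)NO)cc1)c1ncc(-c2ccc(C)cc2)s1` — 4780 nM
compound 2 `Cc1ccc(-c2cnc(N(Cc3ccc(C(=O)NO)cc3)CC(C)C)s2)cc1` — 20400 nM
compound 3 `Cc1ccc(-c2cnc(N(CCCOc3ccccc3)Cc3ccc(C(=O)NO)cc3)s2)cc1` — 2530 nM

In a functional assay on A549 cells (Homo sapiens) for antiproliferative activity, read by MTT assay, with a stated time of 48 h (on this read-out lower numbers stand for stronger inhibition of growth and higher numbers for weaker inhibition of growth), compound 3 gives the lowest of the three numbers; its gap to compound 1 is within the scatter, while an 8.1-fold lower number from compound 2 to compound 3 (0.91 log units; beyond the scatter) lies beyond it.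

Compound 4 `Cc1ccc(-c2cnc(N(Cc3ccccc3)Cc3ccc(C(=O)NO)cc3)s2)cc1` differs from compound 3 in one place: phenyl in place of 2-phenoxyethyl on a saturated chain carbon bound to a nitrogen on an aromatic ring. Cut one bond further out, the same difference reads 3-phenoxypropyl to benzyl.

Two measured steps change the same position. a 1.9-fold lower number from compound 1 to compound 3 (0.28 log units; within the scatter) stayed within the scatter, whereas a 4.3-fold higher number from compound 1 to compound 2 (0.63 log units; beyond the scatter) and an 8.1-fold lower number from compound 2 to compound 3 (0.91 log units; beyond the scatter) were modest. Going by the values given here, no measured step replaces a chain at this position with an aromatic ring, so the expected step of a 1.4-fold higher number from compound 3 to compound 4 (0.14 log units; within the scatter) is small, with wide uncertainty. Compound 4 is estimated at 3500 nM (range 1200 nM to 10000 nM).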

Compound 4, concentration for 50% growth inhibition: 4410 nM
Compound 4: the middle estimate sits 1.3-fold (0.10 log units) below what was measured, within the range that was stated.
By their numbers in this assay, from the lowest: compounds 3, 4 and 1 (each within the scatter of the next); then compound 2.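

In this assay, the benzyl group of compound 4 brings an aromatic ring closer to the nitrogen without the ether oxygen of 3-phenoxypropyl, and the number holds: a 1.7-fold higher number from compound 3 to compound 4 (0.24 log units; within the scatter) and a 1.1-fold lower number from compound 1 to compound 4 (0.03 log units; within the scatter). This position therefore accepts benzyl, butyl-type and 3-phenoxypropyl chains alike, and only compound 2 stands apart, with a 4.6-fold lower number from compound 2 to compound 4 (0.67 log units; beyond the scatter). No available data explain this separation. Open, as far as these compounds go, is whether a terminal amine or carboxylic acid on this chain, or a chain longer than 3-phenoxypropyl, would move the number beyond the scatter.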